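The compounds below may be only part of what the source reports. "The series", "measured", "known", "first", "only" and "open" are said of these compounds alone.

Measured compounds:
compound 1 `CC(C)(/C=C1\OC(=O)NC1=O)c1ccc(-c2ccc3cccc(F)c3c2)[nH]c1=O` with 57 nM
compound 2 `O=C1NC(=O)/C(=C/C(c2ccc(-c3ccc4cccc(F)c4c3)[nH]c2=O)C2CC2)O1` with 33 nM
compound 3 `Cc1cc(C(/C=C2\OC(=O)NC2=O)C(C)C)c(=O)[nH]c1-c1ccc2cccc(F)c2c1` with 92 nM

In a functional assay on CHO cells for antagonist activity at prostaglandin E2 receptor EP3 subtype (Homo sapiens), read by cAMP accumulation, with a stated time of 30 min (on this read-out higher numbers stand for weaker inhibition and lower numbers for stronger inhibition), compound 2 gives 33 nM, the lowest of the three numbers. Compound 1 gives 57 nM, which lies within the scatter of the value of compound 2, so no order between compound 1 and compound 2 can be claimed. Compound 3 gives 92 nM, a higher number that lies beyond the scatter of compound 2; the two differ in more than one place, so this gap cannot be tied to any single change.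

Compound 4 `O=C1NC(=O)/C(=C/C(c2ccc(-c3ccc4cccc(F)c4c3)[nH]c2=O)C2CCCC2)O1` is not yet measured. It differs from compound 2 as follows: cyclopentyl in place of cyclopropyl on a saturated chain carbon bound to an aromatic carbon and a double-bonded chain carbon. Among the measured compounds shown here, no measured pair isolates a change of this kind, so the data give no direction for it. For the measured compounds named here, with the only comparable information being the closeness of compound 1 and compound 2, the expected step is small and not beyond the scatter, in either direction. For compound 4 in this assay the estimate is 40 nM, with a range of 15 nM to 120 nM, which means an expected step of a 1.2-fold higher number from compound 2 to compound 4 (0.08 log units; within the scatter).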

Compound 4, half-maximal inhibitory concentration: 7 nM
Compound 4: the middle estimate sits 5.7-fold (0.76 log units) above what was measured, and the stated range ends above it.
By their numbers in this assay, from the lowest: compound 4; then compounds 2, 1 and 3 (each within the scatter of the next, the first and the last beyond it).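

Among the compounds shown here, the only single-place step, read in this assay, is a 4.7-fold lower number from compound 2 to compound 4 (0.67 log units; beyond the scatter) on replacing cyclopropyl with cyclopentyl, and it lies beyond the scatter. The saturated chain carbon bound to an aromatic carbon and a double-bonded chain carbon is therefore sensitive to the ring it carries, and of these two rings the lower number goes with cyclopentyl, with five heavy atoms against three. Nothing at hand accounts for the direction or size of this step.

Going by these compounds, two ring sizes fix no trend, so it remains open whether cyclohexyl or a straight pentyl chain on this carbon would lower the number further or raise it again. Also open, on these data alone, is whether ring carbon count alone tracks the result, or whether a ring bearing an amine or a carboxylic acid would fit here as well.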